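Swapping fluoro for a second nitrile on the pendant ring

The source may report more compounds than this note shows. Statements on the series, on what has been measured and on what is new or still open speak of the compounds shown alone.

Two compounds with a shared core set the scene. Compound 1 `Cc1ccc2ccc(-c3cccc(CO)c3)cc2n1` gives 8700 nM in a functional assay on CHO cells for inhibition of metabotropic glutamate receptor 5 (Rattus norvegicus), read by FLIPR and calcium flux; on this read-out lower numbers stand for stronger inhibition and higher numbers for weaker inhibition. Compound 2 `Cc1ccc2ccc(-c3cc(F)cc(C#N)c3)cc2n1` gives 0.8 nM in this assay, the lowest of the two numbers and far apart from compound 1, well beyond the scatter of repeated measurements. Compound 3 `Cc1ccc2ccc(-c3cc(C#N)cc(C#N)c3)cc2n1` has not yet been tested. The change from compound 2 to compound 3 is cyano in place of fluoro on an aromatic carbon, so the pendant ring of compound 3 carries two cyano groups. Within the data shown here, no measured pair shows exactly this kind of exchange, so the size of the step can only be guessed. The expectation is that the step from compound 2 to compound 3, estimated as a 1.9-fold higher number from compound 2 to compound 3 (0.27 log units; within the scatter), stays small, not clearly beyond the scatter in either direction. Compound 3 is therefore estimated at 1.5 nM, with a range from 0.3 nM to 8 nM.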

Compound 3, half-maximal inhibitory concentration: 2 nM
Compound 3: the middle estimate sits 1.3-fold (0.12 log units) below what was measured, within the range that was stated.
By their numbers in this assay, from the lowest: compound 2; then compound 3; then compound 1.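

In this assay the exchange of fluoro for cyano gives a 2.5-fold higher number from compound 2 to compound 3 (0.40 log units; beyond the scatter), a modest step that lies just beyond the scatter, and compound 3 still shows a low number of 2 nM on this read-out. This position, meta to a cyano group on the pendant ring, therefore accepts a cyano group of two heavy atoms with one hydrogen-bond acceptor in place of a single fluorine at only a modest cost. No measurement in hand accounts for the size of this step.

From the compounds shown here alone, only fluoro and cyano can be compared at this position, so how an amine, a carboxylic acid or a methoxy group would fare there remains open. Also open, going by these compounds, is whether the same exchange would give a similar step if the remaining cyano group were replaced by another group.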